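Trading a Phenylpiperazine Arm for a Single Bromine Atom

A few compounds are considered here, and "the series" means these few. Any claim that something is new, unique, unknown or untested is made for them only; others in the source may bear on it.

Of the compounds shown here, three sharing one core have been measured in a functional assay on HeLa cells (Homo sapiens) for inhibition, read by MTT assay; a lower number here means a stronger inhibitor, a higher number a weaker inhibitor. Compound 1 `COc1ccccc1N1CCN(CC(=O)Nc2ccc(C(=O)/C=C/c3cn(Cc4ccc(Br)cc4)nn3)cc2)CC1` gives 26400 nM, compound 3 `O=C(CN1CCN(c2ccc([N+](=O)[O-])cc2)CC1)Nc1ccc(C(=O)/C=C/c2cn(Cc3ccc(Br)cc3)nn2)cc1` gives 26600 nM, and compound 2 `O=C(CN1CCN(c2ccccc2)CC1)Nc1ccc(C(=O)/C=C/c2cn(Cc3ccc(Br)cc3)nn2)cc1` gives 79700 nM. Compound 2 stands highest of the three numbers: the step of a 3.0-fold higher number from compound 1 to compound 2 (0.48 log units; beyond the scatter) and the step of a 3.0-fold lower number from compound 2 to compound 3 (0.48 log units; beyond the scatter) each separate it from a neighbour by a modest margin beyond the scatter, while the step of a 1.0-fold higher number from compound 1 to compound 3 (0.00 log units; within the scatter) lies within the scatter, so compound 1 and compound 3 cannot be ordered against each other.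

Compound 4 `O=C(CBr)Nc1ccc(C(=O)/C=C/c2cn(Cc3ccc(Br)cc3)nn2)cc1` differs from compound 2 by bromo in place of 4-phenylpiperazin-1-yl on a saturated chain carbon bound to a carbonyl carbon. For the measured compounds named here, none of the measured steps touches this place; each of them alters only the aromatic ring on the piperazine nitrogen, and even those exchanges, a 3.0-fold higher number from compound 1 to compound 2 (0.48 log units; beyond the scatter) and a 3.0-fold lower number from compound 2 to compound 3 (0.48 log units; beyond the scatter), moved the number only modestly. Going by the values given here, removing the whole arm is a larger change than any that has been tested, so no measured step bears directly on it and the direction is open. Since compound 2 gives 79700 nM and both measured variants sit lower, compound 4 is estimated at 30000 nM, within a range from 8000 nM to 120000 nM, a step of a 2.7-fold lower number from compound 2 to compound 4 (0.42 log units; beyond the scatter) expected to be modest and toward a lower number, held with low confidence.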

Compound 4, half-maximal inhibitory concentration: 7950 nM
Compound 4: middle estimate off by 3.8-fold (0.58 log units), on the high side, outside the stated range (below it).
By their numbers in this assay, from the lowest: compound 4; then compounds 1 and 3 (each within the scatter of the next); then compound 2.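

In this assay, for the compounds shown here, the step at this position, a 10-fold lower number from compound 2 to compound 4 (1.00 log units; beyond the scatter), is larger than either exchange on the aromatic ring of the piperazine, which were a 3.0-fold higher number from compound 1 to compound 2 (0.48 log units; beyond the scatter) and a 3.0-fold lower number from compound 2 to compound 3 (0.48 log units; beyond the scatter), so this place moves the number more than anything the earlier compounds varied. Those compounds all kept the arm and could not show that 4-phenylpiperazin-1-yl, with its 12 heavy atoms and its rings, can give way to bromo on the saturated chain carbon bound to a carbonyl carbon with the number falling rather than rising. Nothing measured here accounts for the size or direction of this step.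

As far as these compounds go, whether the fall belongs to the bromo that enters or to the arm that leaves stays open, since this one exchange changes both at once. A chloro, a hydroxyl or a dimethylamino group on that same carbon would begin to separate the two, and would show whether a small group there is enough or whether bromo itself matters.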